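Shortening a side chain on a core that spares the cells

The compounds below may be only part of what the source reports. "The series", "measured", "known", "first", "only" and "open" are said of these compounds alone.

Three close relatives share a common core. Compound 1 `COc1ccc(-c2cnc(NC(=O)C3CCCCC3)n2C)cc1`, compound 2 `COc1ccc(-c2cnc(NC(=O)c3ccc(F)cc3)n2C(C)C)cc1` and compound 3 `COc1ccc2c(c1)nc(NC(=O)c1ccc(F)cc1)n2C` were each tested in a toxicity assay on THP-1 cells (Homo sapiens) for inhibition; a lower number here means that less compound is tolerated, a higher number that more compound is tolerated. Compound 1 gives only a limit, > 100000 nM. Compound 2 likewise ends at a limit, > 50000 nM. Compound 3 also reaches a limit, > 100000 nM. So compound 2 stands where every value so far stands, at a limit (the limit of > 100000 nM in this assay, at which 2 of the 3 values shown sit, (the limit of > 50000 nM in this assay, at which 1 of the 3 values shown sits)). Compound 4 `CCn1c(-c2ccc(OC)cc2)cnc1NC(=O)c1ccc(F)cc1` differs from compound 2 by one change: hydrogen in place of methyl on a saturated chain carbon bound to an aromatic nitrogen and a saturated chain carbon. Among the measured compounds shown here, no measured pair shows such a change, so no step beyond the scatter is expected in this assay. Compound 4 is estimated at 80000 nM, with a range from 30000 nM to 200000 nM. The expected step is a step that the limit leaves unreadable from compound 2 to compound 4.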

Compound 4, half-maximal cytotoxic concentration: > 100000 nM
Compound 4: no number, only a limit; the forecaster's own chance of this, stated with the estimate: 80%; middle value at least 1.2-fold (0.09 log units) away from the limit.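

Compound 2 and compound 4 both end at limits in this assay, so no step can be read between them. The compounds shown leave open whether changing isopropyl to ethyl alters what the cells tolerate.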